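A few compounds are considered here, and "the series" means these few. Any claim that something is new, unique, unknown or untested is made for them only; others in the source may bear on it.

In a functional assay on T47D cells (Homo sapiens) for inhibition, read by MTT assay, with a stated time of 48 h (a lower number here means a stronger inhibitor, a higher number a weaker inhibitor), three compounds sharing one core have been measured. Compound 1 `CCOC(=O)c1c(N)sc(/N=C/c2ccc(Cl)cc2)c1C(=O)OCC` gives 12100 nM, compound 2 `CCOC(=O)c1c(N)sc(/N=C/c2ccc(Br)cc2)c1C(=O)OCC` gives 13200 nM, and compound 3 `CCOC(=O)c1c(N)sc(/N=C/c2ccncc2)c1C(=O)OCC` gives 8600 nM. Compound 3 stands level with the other two, since a 1.4-fold lower number from compound 1 to compound 3 (0.15 log units; within the scatter) and a 1.5-fold lower number from compound 2 to compound 3 (0.19 log units; within the scatter) both stay within the scatter.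

Compound 4 `CCOC(=O)c1c(N)sc(/N=C/c2ccco2)c1C(=O)OCC` has not yet been measured. It differs from compound 3 by one exchange, furan-2-yl in place of pyridin-4-yl on a carbon with a double bond to nitrogen.

The two steps to compound 3 bear most directly on this exchange. Each replaces the aromatic group at that same carbon. The step of a 1.1-fold higher number from compound 1 to compound 2 (0.04 log units; within the scatter) adds a smaller change on the aromatic group and is just as modest. Among the compounds with values here, no compound with a five-membered aromatic ring at this place has been measured, so the data give only indirect guidance. Going by these compounds, with all three measured steps this small, no step beyond the scatter is expected in this assay, and the direction remains open.

The expected step is a 1.2-fold higher number from compound 3 to compound 4 (0.07 log units; within the scatter). For compound 4 the estimated value is 10000 nM, with an expected range from 5000 nM to 20000 nM.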

Compound 4, half-maximal inhibitory concentration: 14900 nM
Beside the measured number, compound 4's estimate is 1.5-fold (0.17 log units) below it; measured number inside the range.
By their numbers in this assay, from the lowest: compounds 3, 1, 2 and 4 (each within the scatter of the next).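

In this assay, the exchange on a carbon with a double bond to nitrogen now reaches a five-membered aromatic ring, and the furan-2-yl group of compound 4 stands level with all three six-membered aromatic groups (a 1.7-fold higher number from compound 3 to compound 4 (0.24 log units; within the scatter); a 1.2-fold higher number from compound 1 to compound 4 (0.09 log units; within the scatter); a 1.1-fold higher number from compound 2 to compound 4 (0.05 log units; within the scatter)). The earlier compounds shown here showed this tolerance only among six-membered aromatic rings, whereas these steps show that a change in ring size, with oxygen as the hetero atom in place of nitrogen, also stays within the scatter. The information available offers no explanation for these numbers.

The compounds shown therefore leave open whether any group on this carbon can move the number beyond the scatter, for instance a saturated cyclohexyl ring or a phenyl ring carrying a hydroxyl or dimethylamino group. Going by these compounds, the amino group and the two ethyl ester groups stand unchanged across all four compounds, so it also remains open how a carboxylic acid or an amide in place of an ester would read in this assay.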